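Neopentyl for phenyl on two cores in microsomal stability

A few compounds are considered here, and "the series" means these few. Any claim that something is new, unique, unknown or untested is made for them only; others in the source may bear on it.

All values below come from an ADME assay on liver for metabolic stability, with Liver microsome (Homo sapiens) as the target, read by LC-MS, using microsomes; on this read-out lower numbers stand for slow clearance and higher numbers for fast clearance.

compound 1 `O=C(NCc1cc(Cl)ccc1-n1cnnn1)[C@@H]1[C@H]2C[C@H]2CN1C(=O)[C@H](O)c1ccccc1`: 61 mL.min-1.g-1
compound 2 `O=C(NCc1cc(Cl)ccc1-n1cnnn1)[C@@H]1C[C@H]2C[C@H]2N1C(=O)[C@H](O)c1ccccc1`: < 15 mL.min-1.g-1
compound 3 `CC(C)(C)C[C@@H](O)C(=O)N1C[C@@H]2C[C@@H]2[C@H]1C(=O)NCc1cc(Cl)ccc1-n1cnnn1`: 20 mL.min-1.g-1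

Compound 3 differs from compound 1 by neopentyl in place of phenyl on a saturated chain carbon bound to a carbonyl carbon and an oxygen on a saturated carbon. The step is a 3.1-fold lower number from compound 1 to compound 3 (0.48 log units; beyond the scatter).

For compound 2 the result is a limit of the assay and not a number: < 15 mL.min-1.g-1. This is the limit of < 15 mL.min-1.g-1 in this assay, at which 1 of the 3 values shown sits. Compound 1 and compound 2 hold the same atoms joined differently; the difference between the two cores is not broken down here.

Compound 4 `CC(C)(C)C[C@@H](O)C(=O)N1[C@@H]2C[C@@H]2C[C@H]1C(=O)NCc1cc(Cl)ccc1-n1cnnn1` is not yet measured in this assay. It differs from compound 2 by neopentyl in place of phenyl on a saturated chain carbon bound to a carbonyl carbon and an oxygen on a saturated carbon, the same change that turns compound 1 into compound 3, which is where the change occurs in this set. The expectation for compound 4 rests on the step of a 3.1-fold lower number from compound 1 to compound 3 (0.48 log units; beyond the scatter) and on compound 2 already standing at the limit, so no number is likely to be read off in this assay either. Compound 4 is expected to give about 8 mL.min-1.g-1. The expected range for compound 4 runs from 3 mL.min-1.g-1 to 15 mL.min-1.g-1. The step from compound 2 to compound 4 is expected at a step that the limit leaves unreadable from compound 2 to compound 4, though with compound 2 at a limit its true size cannot be fixed. A reported limit, rather than a number, is the most probable outcome for compound 4.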

Compound 4, intrinsic clearance in microsomes: 71 mL.min-1.g-1
Compound 4: the middle estimate sits 8.9-fold (0.95 log units) below what was measured; measured number above the stated range.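

In this assay, neopentyl in place of phenyl does not carry over from one core to the other in this series, and a result on one core gives no safe reading of the same change on the other: the same change on two cores in this assay, a 3.1-fold lower number (0.48 log units; beyond the scatter) from compound 1 to compound 3 and an at least 4.7-fold higher number (0.67 log units; beyond the scatter) from compound 2 to compound 4, at least 14-fold (1.15 log units) apart, beyond the scatter of two such steps

The new step reads an at least 4.7-fold higher number from compound 2 to compound 4 (0.67 log units; beyond the scatter), which fixes only its minimum size, and two matched pairs give neither a rule for further cores nor a reason for the reversal. Compound 2 gives < 15 mL.min-1.g-1, a limit of the assay and not a number.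

Still open, going by these compounds, is whether the split between the cores belongs to neopentyl alone or would also appear with another group at the same place, such as a cyclohexyl ring, a shorter chain like ethyl, or a pyridine ring in place of phenyl, each set on both cores. Also open, on these data alone, is how far the two cores differ from each other with the same group attached, as the limit on compound 2 leaves the phenyl pair without an exact comparison.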